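Trimming the aryl ketone to an aldehyde

The source may report more compounds than this note shows. Statements on the series, on what has been measured and on what is new or still open speak of the compounds shown alone.

Compound 1, `CC1(C)C=C(n2ccccc2=O)c2cc(C(=O)c3cccs3)ccc2O1`, gives 6.4 in a functional assay (aorta) with Rattus norvegicus as the target; on this read-out lower numbers stand for lower potency and higher numbers for higher potency (the scale is a negative logarithm).
Compound 2, `CC1(C)C=C(n2ccccc2=O)c2cc(C(=O)c3ccc([N+](=O)[O-])cc3)ccc2O1`, gives 6.2 in this assay.
Compound 3, `Cc1ccccc1C(=O)c1ccc2c(c1)C(n1ccccc1=O)=CC(C)(C)O2`, gives 6.83 in this assay.

Compound 3 stands highest of the three; compound 1 lies nearest and compound 2 furthest, and both distances are beyond the scatter. Its closest analogues differ only at the carbonyl carbon: a number 0.43 log units higher from compound 1 to compound 3 (beyond the scatter) and a number 0.63 log units higher from compound 2 to compound 3 (beyond the scatter), while a number 0.20 log units lower from compound 1 to compound 2 (within the scatter). Compound 4, `CC1(C)C=C(n2ccccc2=O)c2cc(C=O)ccc2O1`, is reached from compound 3 by hydrogen in place of 2-methylphenyl on a carbonyl carbon. Among the measured compounds shown here, none of the measured steps removes the ring at this carbon; they only exchange one ring for another and give modest changes in this assay. The loss of the whole 2-methylphenyl group is a larger change than any of them, and the three measured compounds do not show what a formyl group does here. Compound 4 is therefore expected to fall, with the step of a number 1.23 log units lower from compound 3 to compound 4 (beyond the scatter) carrying wide uncertainty. Compound 4 is estimated at 5.6, within 4.8 to 6.4.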

Compound 4, logarithm of the reciprocal of the active concentration, log(1/C): 6.91
Estimate against measurement, compound 4: 1.31 log units below; the measured number lies above the stated range.
By their numbers in this assay, from the lowest: compounds 2 and 1 (each within the scatter of the next); then compounds 3 and 4 (each within the scatter of the next).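

In this assay the ring on the carbonyl carbon proves dispensable: the full loss of 2-methylphenyl reads a number 0.08 log units higher from compound 3 to compound 4 (within the scatter) and leaves a bare formyl group. The same exchange on the other two ketones reads a number 0.71 log units higher from compound 2 to compound 4 (beyond the scatter) and a number 0.51 log units higher from compound 1 to compound 4 (beyond the scatter), so among these compounds no ring at this carbon lifts the number beyond the scatter above that of the formyl compound, and two of the three rings sit lower. Nothing available here explains this result.

The compounds shown leave open whether the carbonyl itself counts at this position, which a hydroxymethyl group, a nitrile or a carboxylic acid in place of formyl would test. Also open, going by these compounds, is whether an acetyl group, a ketone with a methyl in place of the ring, would read like compound 4 or like the ring ketones.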